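Adding a Hydroxy to the Chain of Compound 2

The source may hold more compounds than are shown below. What is called first, only, known or untested is meant among the compounds shown, and "the series" means these compounds.

Of the compounds shown here, two with the same core and different chains have been measured so far in an in vivo ADME assay on the whole organism (strain C57) for pharmacokinetics, with Mus musculus as the target; on this read-out higher numbers stand for higher oral bioavailability and lower numbers for lower oral bioavailability. Compound 1 `Cn1c(-c2ccccc2C(F)(F)F)nnc1C12CCC(CCCC(C)(F)F)(CC1)CC2` gives 36%, and compound 2 `CCCCCC12CCC(c3nnc(-c4ccccc4C(F)(F)F)n3C)(CC1)CC2` gives 20%, which makes compound 2 the lower of the pair. Within the data shown here, the single measured step is a number 16 percentage points lower from compound 1 to compound 2 (beyond the scatter), a modest change in which ethyl takes the place of 1,1-difluoroethyl on the chain.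

Compound 3 `CC(O)CCCC12CCC(c3nnc(-c4ccccc4C(F)(F)F)n3C)(CC1)CC2` keeps the chain of compound 2 but changes it in one place: hydroxy in place of hydrogen on a saturated chain carbon bound to two saturated chain carbons. In words, hydroxy stands in place of hydrogen on a saturated chain carbon bound to two saturated chain carbons. Among the measured compounds shown here, no measured compound carries a hydroxy, so the step to compound 1, a number 16 percentage points lower from compound 1 to compound 2 (beyond the scatter), is only a loose guide. It shows that a change on this chain can move this assay by a modest amount, but it does not fix the direction for hydroxy. The expected step is therefore small and slightly upward, a number 4 percentage points higher from compound 2 to compound 3 (within the scatter), though a fall is possible. Compound 3 is estimated at 24%, with an expected range of 8% to 45%.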

Compound 3, oral bioavailability: 21%
Compound 3: middle estimate off by 3 percentage points, on the high side, within the range that was stated.
By their numbers in this assay, from the lowest: compounds 2 and 3 (each within the scatter of the next); then compound 1.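

In this assay, hydroxy in place of hydrogen on a saturated chain carbon bound to two saturated chain carbons gives a number 1 percentage points higher from compound 2 to compound 3 (within the scatter) and so leaves compound 3 indistinguishable from compound 2 on this read-out. Among these compounds, this is the first sign that a hydroxy at this place does not bring the number back towards that of compound 1, as the comparison with the 1,1-difluoroethyl chain also shows: a number 15 percentage points lower from compound 1 to compound 3 (beyond the scatter) is a step of nearly the same size as a number 16 percentage points lower from compound 1 to compound 2 (beyond the scatter) and, like it, lies beyond the scatter. Among these three chains, then, only the 1,1-difluoroethyl chain stands apart, while ethyl and 1-hydroxyethyl at its end cannot be separated, and no supporting data bear on what lies behind these numbers.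

Still open, from the compounds shown here alone, is whether an amine or a carboxylic acid at this same chain carbon would behave as the hydroxy does here, or would move the number beyond the scatter. Also open, going by these compounds, is whether a single fluorine at this carbon, or a longer chain, would come closer to compound 1 or stay with compound 2 and compound 3.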